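This account rests on a few compounds, and the source may have more. Where it says the series, first, only, none or still open, it means among the compounds named here.

Measured so far in a functional assay on HepG2 cells (Homo sapiens) for cytotoxicity, read by MTT assay, with a stated time of 24 h; a higher number here means a weaker inhibitor, a lower number a stronger inhibitor:

compound 1 `COc1cc(/C=C2\CN(C)C/C(=C\c3ccc(Br)cc3)C2=O)cc(OC)c1OC`: 6800 nM
compound 2 `COc1cc(/C=C2\CN(C)C/C(=C\c3ccc(Cl)cc3Cl)C2=O)cc(OC)c1OC`: 8800 nM
compound 3 `CN1C/C(=C\c2ccc(Br)cc2)C(=O)/C(=C/c2cccc([N+](=O)[O-])c2)C1`: 8800 nM

Compound 1 and compound 2 share a core and differ only by 2,4-dichlorophenyl in place of 4-bromophenyl on a double-bonded chain carbon bound to a double-bonded ring carbon; this change gave a 1.3-fold higher number from compound 1 to compound 2 (0.11 log units; within the scatter). Compound 3 rests on a different core, and the difference between the two cores is not broken down here; in this assay the numbers of compound 3 and compound 2 lie within the scatter of each other.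

Not yet measured is compound 4 `CN1C/C(=C\c2cccc([N+](=O)[O-])c2)C(=O)/C(=C/c2ccc(Cl)cc2Cl)C1`. It differs from compound 3 by 2,4-dichlorophenyl in place of 4-bromophenyl on a double-bonded chain carbon bound to a double-bonded ring carbon, at a place described in the same words as for the first pair, so this is the same change. For compound 4 the expected step is a 1.3-fold higher number from compound 3 to compound 4 (0.10 log units; within the scatter), set beside a 1.3-fold higher number from compound 1 to compound 2 (0.11 log units; within the scatter), because the same change once gave a 1.3-fold higher number from compound 1 to compound 2 (0.11 log units; within the scatter). Compound 4 is therefore estimated at 11000 nM, with a range from 5500 nM to 22000 nM.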

Compound 4, half-maximal inhibitory concentration: 4800 nM
The estimate for compound 4 lay 2.3-fold (0.36 log units) above the measured number; measured number outside the range, below it.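

In this assay, 2,4-dichlorophenyl in place of 4-bromophenyl on a double-bonded chain carbon bound to a double-bonded ring carbon gave a 1.8-fold lower number from compound 3 to compound 4 (0.26 log units; within the scatter). Set beside the earlier step, the result on the two cores cannot be told apart: the same change on two cores in this assay, a 1.3-fold higher number (0.11 log units; within the scatter) from compound 1 to compound 2 and a 1.8-fold lower number (0.26 log units; within the scatter) from compound 3 to compound 4, 2.4-fold (0.38 log units) apart, within the scatter of two such steps. This shows no difference between the cores in how the change carries over, but it does not show that the change has the same effect on both, or any effect at all, since one pair per core stays within the scatter.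

The compounds shown leave open whether any change at this place gives a step beyond the scatter. A carboxylic acid or an amine on the phenyl ring there could test this.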